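The source may hold more compounds than are shown below. What is called first, only, known or untested is meant among the compounds shown, and "the series" means these compounds.

Measured in a functional assay on NCI-H460 cells (Homo sapiens) for cytotoxicity, read by MTT assay, with a stated time of 72 h; a lower number here means a stronger inhibitor, a higher number a weaker inhibitor:
- compound 1 `CCCCCCCCNC1=CC(=O)C=C(C[C@]2(C)[C@@H](C)CC[C@]3(C)C(C)=CCC[C@@H]23)C1=O`: 35000 nM
- compound 2 `CCCCNC1=CC(=O)C=C(C(C)(C)C)C1=O`: 13000 nM
- compound 3 `CCCCNC1=CC(=O)C(C[C@]2(C)[C@@H](C)CC[C@]3(C)C(C)=CCC[C@@H]23)=CC1=O`: > 100000 nM

Of the two exact numbers, compound 2 has the lower, and compound 1, the nearest, lies beyond the usual scatter from it. For compound 3 the reading is a limit of the assay, not a number. Compound 4 `CCCCCCCCNC1=CC(=O)C=C(C(C)(C)C)C1=O` departs from compound 2 by butyl in place of hydrogen on a saturated chain carbon, four bonds along the chain from an amine nitrogen, with butyl in place of hydrogen on a saturated chain carbon, four bonds along the chain from an amine nitrogen. The longer amine chain of compound 4 also occurs in compound 1, which gives 35000 nM on a different core. No step beyond the scatter is therefore expected in this assay. The expected step of a 1.3-fold lower number from compound 2 to compound 4 (0.11 log units; within the scatter) is small, and if real, it would most likely run toward a lower number. For compound 4 the estimated value is 10000 nM, with an expected range of 3000 nM to 35000 nM.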

Compound 4, half-maximal inhibitory concentration: 21000 nM
Beside the measured number, compound 4's estimate is 2.1-fold (0.32 log units) below it, and the stated range covers the measured number.
By their numbers in this assay, from the lowest: compounds 2, 4 and 1 (each within the scatter of the next, the first and the last beyond it). At a limit, above all of these: compound 3.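

In this assay, butyl in place of hydrogen on a saturated chain carbon, four bonds along the chain from an amine nitrogen, gives a 1.6-fold higher number from compound 2 to compound 4 (0.21 log units; within the scatter). Within the data shown here, this is the first comparison of the two amine chains on one shared core, and the two compounds cannot be told apart at this place. Nothing measured here speaks to a cause for this result.

The compounds shown leave open whether a hexyl chain, or a chain ending in an amine or a carboxylic acid, would read alike on the shared core.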